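This account rests on a few compounds, and the source may have more. Where it says the series, first, only, none or still open, it means among the compounds named here.

Measured so far in a functional assay on SH-SY5Y cells (Homo sapiens) for antiproliferative activity, read by MTT assay, with a stated time of 72 h; a higher number here means a weaker inhibitor, a lower number a stronger inhibitor:
compound 1 `O=[N+]([O-])c1ccc(COc2ccc(Nc3ncnc4cc5c(cc34)OCCOCCO5)cc2)cc1`; compound 1 gives 55200 nM.
compound 3 `FC(F)(F)c1ccc(COc2ccc(Nc3ncnc4cc5c(cc34)OCCOCCO5)cc2)cc1`; compound 3 gives 30400 nM.
compound 2 `FC(F)(F)c1ccc(COc2ccccc2Nc2ncnc3cc4c(cc23)OCCOCCO4)cc1`; for compound 2 the assay gives only a limit, > 100000 nM.

Compound 3 and compound 1 differ by one change, (nitro in place of trifluoromethyl on an aromatic carbon), and this change made a 1.8-fold higher number from compound 3 to compound 1 (0.26 log units; within the scatter). The cores of compound 2 and compound 3 are built from the same atoms joined differently; that difference is not broken down here. Compound 4 `O=[N+]([O-])c1ccc(COc2ccccc2Nc2ncnc3cc4c(cc23)OCCOCCO4)cc1` has not been measured in this assay. It stands to compound 2 as compound 1 stands to compound 3: nitro in place of trifluoromethyl on an aromatic carbon. The same change is therefore made twice in the series. Because compound 2 already sits at the limit of > 100000 nM in this assay, at which 1 of the 3 values shown sits, a step of the size seen between compound 3 and compound 1 would leave compound 4 at or beyond that limit. The step from compound 2 to compound 4 is expected to be a step that the limit leaves unreadable from compound 2 to compound 4. Compound 4 is expected near 160000 nM, between 70000 nM and 400000 nM, most likely reported only as a limit.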

Compound 4, half-maximal inhibitory concentration: > 100000 nM
Compound 4: a limit, no number; the forecaster's own chance of this, stated with the estimate: 80%; the middle value does not contradict the limit.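

Compound 2 and compound 4 both stand only as limits in this assay, so no step between them can be read: the limit of > 100000 nM in this assay, at which 2 of the 4 values shown sit.

The compounds shown leave open whether nitro in place of trifluoromethyl does the same in this pair as between compound 3 and compound 1.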